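The compounds below may be only part of what the source reports. "The series", "measured", "known", "first", "only" and "open" are said of these compounds alone.

Compound 1 `Cc1nc(COc2ccc(/C=C3\SC(=O)NC3=O)cc2)cs1` gives 14.7%.
Compound 2 `Cc1ccc(-c2nnc(SCCOc3ccc(/C=C4\SC(=O)NC4=O)cc3)[nH]2)cc1` gives 22.6%.
Compound 3 `O=C1NC(=O)/C(=C/c2ccc(OCCSc3nnc(-c4ccccc4)o3)cc2)S1` gives 16.1%.

In a functional assay on the whole organism (plasma, strain Wistar) with Rattus norvegicus as the target, with a stated time of 15 days, at a dose of 30 mg/kg by the oral route (a higher number here means a stronger effect of the compound at the dose given, a lower number a weaker effect), the three measured compounds lie close together. Compound 3 sits with compound 1 and compound 2 inside the usual scatter: its number is nearest to that of compound 1, a little lower, and furthest from that of compound 2, somewhat higher, yet neither gap is beyond the scatter. Among the compounds with values here, no single-point step has been measured among them, so there is no measured step to guide the next change.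

Compound 4 `O=C1NC(=O)/C(=C/c2ccc(OCCSc3nnc(-c4ccncc4)o3)cc2)S1` differs from compound 3 in one place: pyridin-4-yl in place of phenyl on an aromatic carbon. Within the data shown here, with no measured step to lean on and the three numbers so close, the step of a number 0.9 percentage points higher from compound 3 to compound 4 (within the scatter) is expected to stay within the scatter, in no clear direction. Compound 4 is therefore estimated at 17%, with a range from 7% to 29%.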

Compound 4, a percentage reported as activity, at one dose (the size of the read-out at that dose, not a potency): 40%
For compound 4 the middle estimate is 23 percentage points below the measured one; measured number outside the range, above it.
By their numbers in this assay, from the lowest: compounds 1, 3 and 2 (each within the scatter of the next); then compound 4.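

In this assay pyridin-4-yl in place of phenyl on an aromatic carbon gives a number 23.9 percentage points higher from compound 3 to compound 4 (beyond the scatter) and so provides the first single-place step among these compounds. It shows that this position can respond strongly to a change that keeps the count of heavy atoms, replacing one ring carbon with nitrogen and adding one hydrogen-bond acceptor. Nothing measured here explains the rise.

On these data alone, it remains open whether pyridin-3-yl or pyridin-2-yl at this position would give a similar result. A single step also cannot show whether an aminophenyl group would do the same.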